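Swapping the Aryl Group on the Amine of Compound 1

The source may hold more compounds than are shown below. What is called first, only, known or untested is meant among the compounds shown, and "the series" means these compounds.

Compound 1 `C=C1[C@@H](OC(C)=O)C[C@@H]2[C@](C)(CO[Si](C)(C)C(C)(C)C)[C@H](OC(C)=O)CC[C@@]2(C)[C@@H]1C[C@@H](Nc1cccc(F)c1)C1=CCOC1=O` gives 4560 nM in a functional assay on KB cells (Homo sapiens) for cytotoxicity, read by sulforhodamine B assay; a higher number here means a weaker inhibitor, a lower number a stronger inhibitor.
Compound 2 `C=C1[C@@H](OC(C)=O)C[C@@H]2[C@](C)(COC=O)[C@H](OC(C)=O)CC[C@@]2(C)[C@@H]1C[C@@H](Nc1ccc(OC)cc1)C1=CCOC1=O` gives 32700 nM in this assay.
Compound 3 `C=C1[C@@H](OC(C)=O)C[C@@H]2[C@](C)(COC=O)[C@H](OC(C)=O)CC[C@@]2(C)[C@@H]1C[C@@H](Nc1cccc(F)c1)C1=CCOC1=O` gives 28600 nM in this assay.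

Compound 1 holds the lowest of the three numbers in this assay and is therefore the strongest inhibitor of the set. Its nearest neighbour is compound 3, reached by a 6.3-fold higher number from compound 1 to compound 3 (0.80 log units; beyond the scatter), a change that sits on an oxygen on a saturated carbon, far from the amine. Compound 2 shows a still higher number than compound 1.

Compound 4 `C=C1[C@@H](OC(C)=O)C[C@@H]2[C@](C)(CO[Si](C)(C)C(C)(C)C)[C@H](OC(C)=O)CC[C@@]2(C)[C@@H]1C[C@@H](Nc1ccc(O)cc1)C1=CCOC1=O` keeps the larger silicon-containing group of compound 1 and changes only the aryl group on the amine nitrogen: 4-hydroxyphenyl in place of 3-fluorophenyl on an amine nitrogen.

Of the two measured steps, only one touches the amine. That step, a 1.1-fold lower number from compound 2 to compound 3 (0.06 log units; within the scatter), swapped one aryl group for another on the same nitrogen and stayed within the scatter, though it was seen on compounds carrying the smaller group on the oxygen. The step into compound 3 from compound 1 concerns a different part of the core and is not informative here. On this basis compound 4 is expected to sit close to compound 1, with a step of a 1.1-fold higher number from compound 1 to compound 4 (0.04 log units; within the scatter) judged most likely to be no larger than the scatter. Compound 4 is estimated at 5000 nM, within a range of 1500 nM to 16000 nM.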

Compound 4, half-maximal inhibitory concentration: 8350 nM
Compound 4: the middle estimate sits 1.7-fold (0.22 log units) below what was measured; the range from low to high includes it.
By their numbers in this assay, from the lowest: compounds 1 and 4 (each within the scatter of the next); then compounds 3 and 2 (each within the scatter of the next).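

With the silicon-containing group kept in place, the step of a 1.8-fold higher number from compound 1 to compound 4 (0.26 log units; within the scatter) shows that in this assay the amine nitrogen takes 4-hydroxyphenyl in place of 3-fluorophenyl without a clear difference. Going by these compounds alone, the earlier aryl swap of a 1.1-fold lower number from compound 2 to compound 3 (0.06 log units; within the scatter) was seen only on compounds carrying the smaller group on the oxygen, so the same absence of a clear difference now holds on both versions of that oxygen substituent, even though 4-hydroxyphenyl counts 1 hydrogen-bond donor and 1 hydrogen-bond acceptor where 3-fluorophenyl counts none. Nothing measured here explains why this swap leaves the number within the scatter.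

Going by these compounds, all the groups compared on this nitrogen are substituted phenyl rings, so it remains open whether a non-aromatic group such as cyclohexyl, or a ring holding nitrogen such as pyridyl, would stay within the scatter as well. On these data alone, it is also open whether a phenyl ring bearing a carboxylic acid or an amine would do the same, and whether 4-hydroxyphenyl would behave alike on the compounds with the smaller group on the oxygen.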